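Carbamate change from compound 2 to compound 4: opening notes

The source may hold more compounds than are shown below. What is called first, only, known or untested is meant among the compounds shown, and "the series" means these compounds.

Measured compounds:
compound 1 `CC(C)(C)OC(=O)N1CCC(O[C@H]2CC[C@H](Oc3ccc(S(C)(=O)=O)cn3)CC2)CC1` – 110 nM
compound 2 `CC(C)(C)OC(=O)N1CCC(O[C@H]2CC[C@H](Oc3cnc(S(C)(=O)=O)cn3)CC2)CC1` – 64 nM
compound 3 `CC(C)(C)OC(=O)N1CCC(O[C@H]2CC[C@H](Oc3ccc(S(C)(=O)=O)nn3)CC2)CC1` – 1160 nM

In a functional assay on isolated protein for agonist activity at Glucose-dependent insulinotropic receptor (Rattus norvegicus), read by HTRF and cAMP accumulation (a higher number here means that more compound is needed for the effect, a lower number that less compound is needed), compound 2 gives 64 nM, the lowest number of the three. The step of a 1.7-fold lower number from compound 1 to compound 2 (0.24 log units; within the scatter) lies within the scatter, so compound 1 and compound 2 cannot be ordered. The steps of an 11-fold higher number from compound 1 to compound 3 (1.02 log units; beyond the scatter) and an 18-fold higher number from compound 2 to compound 3 (1.26 log units; beyond the scatter) are both large, so compound 3 stands apart from the other two.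

Compound 4 `C[C@@H](CF)OC(=O)N1CCC(O[C@H]2CC[C@H](Oc3cnc(S(C)(=O)=O)cn3)CC2)CC1` differs from compound 2 by 1-(fluoromethyl)ethyl in place of tert-butyl on an oxygen next to a carbonyl group. All three measured steps change only the group on the oxygen on a saturated carbon; none touches the carbamate end of the molecule. Among the compounds with values here, no measured step therefore bears on this change, and the expectation rests on compound 2 alone. The step of no change at the digits printed from compound 2 to compound 4 (within the scatter) is expected to stay within the scatter, with no direction assumed. Within the data shown here, for compound 4 the estimate in this assay is 64 nM, with a range of 25 nM to 160 nM; no comparable step exists, so the range is wide.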

Compound 4, half-maximal effective concentration: 356 nM
Compound 4: the middle estimate sits 5.6-fold (0.75 log units) below what was measured, outside the stated range (above it).
By their numbers in this assay, from the lowest: compounds 2 and 1 (each within the scatter of the next); then compound 4; then compound 3.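

In this assay, the carbamate end responds to substitution: there is a 5.6-fold higher number from compound 2 to compound 4 (0.75 log units; beyond the scatter), with 1-(fluoromethyl)ethyl in place of tert-butyl on an oxygen next to a carbonyl group. Within the data shown here, the earlier steps changed only the group on the oxygen on a saturated carbon, so this is the first measured step at this end. It moves the number beyond the scatter even though both groups have the same heavy-atom count and neither has hydrogen-bond donors or acceptors, and nothing available accounts for the step.

Still open, from the compounds shown here alone, is whether the fluorine, the defined stereocentre or the change in the carbon count carries the step; an isopropyl carbamate and the mirror-image 1-(fluoromethyl)ethyl carbamate would help separate these. Also open, going by these compounds, is whether the step carries over to the cores of compound 1 and compound 3.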